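This account rests on a few compounds, and the source may have more. Where it says the series, first, only, none or still open, it means among the compounds named here.

Measured set:
- compound 1, `O=C(Nc1cccc(-n2cc(-c3ccncc3)c(-c3cc(O)cc(Cl)c3)n2)c1)Nc1ccc(Cl)c(C(F)(F)F)c1`: in a functional assay on U-251 cells (Homo sapiens) for inhibition, read by sulforhodamine B assay, with a stated time of 48 h, tested at 0.1 uM (on this read-out lower numbers stand for a stronger effect and higher numbers for a weaker effect at the one concentration tested), compound 1 gives 91%
- compound 2, `O=C(Nc1cccc(-n2cc(-c3ccncc3)c(-c3cc(O)cc(Cl)c3)n2)c1)Nc1ccc(Cl)c(Cl)c1`: compound 2 gives 93%
- compound 3, `COc1cc(Cl)cc(-c2nn(-c3cccc(NC(=O)Nc4ccc(Cl)c(C(F)(F)F)c4)c3)cc2-c2ccncc2)c1`: compound 3 gives 92%

All three numbers sit close together. Compound 3 stands second highest of the three, with compound 1 nearest and compound 2 furthest, both gaps within the scatter. Among the measured compounds shown here, the only two steps that can be read off are small: a number 2 percentage points higher from compound 1 to compound 2 (within the scatter) and a number 1 percentage points higher from compound 1 to compound 3 (within the scatter). Neither moves the read-out beyond the scatter.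

Compound 4, `COc1cc(Cl)cc(-c2nn(-c3cccc(NC(=O)Nc4ccc(Cl)c(Cl)c4)c3)cc2-c2ccncc2)c1`, has not been measured. It differs from compound 3 in one place: chloro in place of trifluoromethyl on an aromatic carbon. This is the same change as the measured step from compound 1 to compound 2, made on the compound that carries methyl on the oxygen instead of hydrogen. That measured step was within the scatter, and the methyl-for-hydrogen step was likewise within the scatter, so the two changes have shown no sign of interacting. Compound 4 is therefore expected to sit at the same level as compound 3, with a step of a number 2 percentage points higher from compound 3 to compound 4 (within the scatter) that stays within the scatter. The estimate for compound 4 in this assay is 94%, between 84% and 102%.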

Compound 4, a percentage reported as activity, at one concentration (the size of the read-out at that concentration, not a potency): 92%
Beside the measured number, compound 4's estimate is 2 percentage points above it; low and high end bracket the measured number.
By their numbers in this assay, from the lowest: compounds 1, 3, 4 and 2 (each within the scatter of the next).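

In this assay, the change from trifluoromethyl to chloro on this aromatic carbon, ortho to a chloro group, can now be read on a second core, the one with methyl on the oxygen, as no change at the digits printed from compound 3 to compound 4 (within the scatter). Its size does not depend measurably on which core carries it: the same change on two cores in this assay, a number 2 percentage points higher (within the scatter) from compound 1 to compound 2 and no change at the digits printed (within the scatter) from compound 3 to compound 4, 2 percentage points apart, within the scatter of two such steps The methyl-for-hydrogen change on the oxygen likewise gains a second reading, now with the 3,4-dichlorophenyl group in place of the 4-chloro-3-(trifluoromethyl)phenyl group, as a number 1 percentage points lower from compound 2 to compound 4 (within the scatter), and it also holds across the two: the same change on two cores in this assay, a number 1 percentage points higher (within the scatter) from compound 1 to compound 3 and a number 1 percentage points lower (within the scatter) from compound 2 to compound 4, 2 percentage points apart, within the scatter of two such steps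

On these data alone, whether an amine or a carboxylic acid on this aromatic carbon, or a longer chain on the oxygen, would move the read-out beyond the scatter stays open, since the two groups compared at each place give indistinguishable numbers. As far as these compounds go, the read-out comes from a single concentration and gives no potency, so any difference between these compounds at other concentrations also remains unknown.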